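From compound 3 to compound 4 in a cell assay

The source may report more compounds than this note shows. Statements on the series, on what has been measured and on what is new or still open speak of the compounds shown alone.

Compound 1 `CC(C)(C)c1ccc(NC(=O)c2cc(=O)[nH]c3cc(Br)ccc23)cc1`: in a functional assay on KYSE-410 cells (Homo sapiens) for antiproliferative activity, read by MTT assay, with a stated time of 72 h (a higher number here means a weaker inhibitor, a lower number a stronger inhibitor), compound 1 gives > 20000 nM, a limit of the assay.
Compound 2 `O=C(Nc1cc(F)cc(F)c1)c1cc(=O)[nH]c2cc(O)ccc12`: in this assay compound 2 gives > 20000 nM, also a limit.
Compound 3 `O=C(Nc1cccc(F)c1)c1cc(=O)[nH]c2cc(-c3cccc(F)c3)ccc12`: in this assay compound 3 gives 10900 nM.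

Going by the values given here, compound 3 thus holds the only real number among the three; the other two sit at the limit of > 20000 nM in this assay, at which 2 of the 3 values shown sit. Compound 4 `Cc1cc(-c2ccc3c(C(=O)Nc4cccc(F)c4)cc(=O)[nH]c3c2)c(C)cc1F` differs from compound 3 in one place: 4-fluoro-2,5-dimethylphenyl in place of 3-fluorophenyl on an aromatic carbon. No measured step joins any two of these compounds, so nothing measured tells the size of such a change. Only a small step is expected, a 1.4-fold lower number from compound 3 to compound 4 (0.13 log units; within the scatter), either within the scatter or a modest gain. Compound 4 is estimated at 8000 nM, with a range from 2500 nM to 20000 nM.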

Compound 4, half-maximal inhibitory concentration: > 20000 nM
Compound 4: no number, only a limit; the forecaster's own chance of this, stated with the estimate: 30%; middle value at least 2.5-fold (0.39 log units) away from the limit.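

Going by these compounds alone, replacing 3-fluorophenyl with 4-fluoro-2,5-dimethylphenyl on this aromatic carbon in this assay gives the first measured step at this position, an at least 1.8-fold higher number from compound 3 to compound 4 (0.26 log units; that floor lies within the scatter), with a single substitution. Compound 4 gives only a limit, so this step is a floor: the change brought no visible gain, but a real loss is not established. Compound 4 now stands with the other compounds at the limit: the limit of > 20000 nM in this assay, at which 3 of the 4 values shown sit.

The compounds shown leave open whether an amine or a carboxylic acid on this ring would change the number of compound 3. They also leave open whether a methyl group alone would do so.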